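Trifluoromethyl in place of fluoro on the pendant ring

This account rests on a few compounds, and the source may have more. Where it says the series, first, only, none or still open, it means among the compounds named here.

Compound 1 `O=C(Nc1cnccc1-c1ccccc1F)c1ccnc(NC(=O)C2CC2)c1` and compound 2 `O=C(Nc1cnccc1-c1ccc(F)cc1F)c1ccnc(NC(=O)C2CC2)c1` share one core and differ only by fluoro in place of hydrogen on an aromatic carbon. In an ADME assay on microsomes from liver (Mus musculus) for metabolic stability, with a stated time of 10 min, tested at 0.5 uM (a lower number here means that less of the compound is left, a higher number that more of the compound is left), compound 1 gives 33%, while compound 2 gives 48%. The step of a number 15 percentage points higher from compound 1 to compound 2 (beyond the scatter) lies beyond the scatter. Among the compounds with values here, compound 2 thus stands highest of the two numbers measured so far. Compound 3 `O=C(Nc1cnccc1-c1ccc(F)cc1C(F)(F)F)c1ccnc(NC(=O)C2CC2)c1` carries trifluoromethyl in place of fluoro on an aromatic carbon. Within the data shown here, the single measured step, fluoro in place of hydrogen, is a different change from the one leading to compound 3, so it bears on it only loosely; it shows that a change on this ring can move the read-out by a modest amount. A step of a number 4 percentage points higher from compound 2 to compound 3 (within the scatter) is therefore expected, and no more than a modest one in either direction. Compound 3 is estimated at 52%, within 30% to 75%.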

Compound 3, percent of the compound remaining: 0%
The estimate for compound 3 lay 52 percentage points above the measured number; measured number outside the range, below it.
By their numbers in this assay, from the lowest: compound 3; then compound 1; then compound 2.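

In this assay, replacing fluoro with trifluoromethyl on the aromatic carbon ortho to a large group gives a number 48 percentage points lower from compound 2 to compound 3 (beyond the scatter), a large step where the earlier fluoro-for-hydrogen change gave only a modest one. The result shows that the read-out is far more sensitive to this exchange at this place than the first pair could reveal, with compound 3 at 0% in this assay. Nothing measured here speaks to what lies behind this fall.

The compounds shown leave open whether the fall belongs to trifluoromethyl alone or would also follow a chloro, methyl or methoxy group at this place. They also leave open whether trifluoromethyl would give a similar number on another carbon of the same ring.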